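Ester variation on the shared core against hexokinase-2

A few compounds are considered here, and "the series" means these few. Any claim that something is new, unique, unknown or untested is made for them only; others in the source may bear on it.

Measured compounds:
compound 1 `C=C1CC[C@H]2[C@@](C)(CCC(=O)N[C@@]2(C)COC(=O)c2ccccc2)[C@@H]1/C=C/C1=CCOC1=O` — > 50000 nM
compound 2 `C=C1CC[C@H]2[C@@](C)(CCC(=O)N[C@@]2(C)COC(=O)[C@@H]2CCCN2)[C@@H]1/C=C/C1=CCOC1=O` — > 50000 nM

In an assay for inhibition of hexokinase-2 (Homo sapiens), read by coupled enzyme assay, with a stated time of 10 min, in the presence of a further agent that is not named here (a lower number here means a stronger inhibitor, a higher number a weaker inhibitor), compound 1 gives only a limit, > 50000 nM. Compound 2 likewise gives only a limit in this assay, > 50000 nM. The step that the two limits leave unreadable from compound 1 to compound 2 therefore cannot be read in size or direction, since both of its ends sit at the limit of > 50000 nM in this assay, at which 2 of the 2 values shown sit.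

Compound 3 `C=C1CC[C@H]2[C@@](C)(CCC(=O)N[C@@]2(C)COC(=O)CCCC[C@@H]2CCSS2)[C@@H]1/C=C/C1=CCOC1=O` differs from compound 1 by a group of 9 heavy atoms (7 carbon, 2 sulfur; one five-membered non-aromatic ring with 2 hetero atoms) in place of a group of 6 heavy atoms (6 carbon; one six-membered aromatic ring of carbon only), on a carbonyl carbon. This is again an exchange of the group on the carbonyl carbon of the ester, the same place that was altered from compound 1 to compound 2. Among the compounds with values here, the one measured step that bears on it gave no readable size, and there is no measured value beyond the limit anywhere; the change to compound 3 is thus without precedent in the numbers at hand. No step beyond the scatter in this assay is expected from compound 1 to compound 3, and the most probable outcome is a further limit. For compound 3 the expected value in this assay is 100000 nM (range 30000 nM to 400000 nM), which corresponds to an expected step that the limit leaves unreadable from compound 1 to compound 3.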

Compound 3, half-maximal inhibitory concentration: 9360 nM
For compound 3 the middle estimate is 11-fold (1.03 log units) above the measured one; the measured number lies below the stated range.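

In this assay the group on the carbonyl carbon of the ester now proves able to move the read-out: the group of 9 heavy atoms, with its five-membered non-aromatic ring with 2 hetero atoms, gives an at least 5.3-fold lower number from compound 1 to compound 3 (0.72 log units; beyond the scatter) in place of phenyl and an at least 5.3-fold lower number from compound 2 to compound 3 (0.72 log units; beyond the scatter) in place of pyrrolidin-2-yl. The earlier pair could not show this, as its step between two limits had no readable size or direction. Both new steps are therefore minimum sizes, and compound 3 is the only compound shown with a value that is not a limit: the limit of > 50000 nM in this assay, at which 2 of the 3 values shown sit.

Going by these compounds, what remains open is which part of the entering group goes with the step, as compound 3 brings in the sulfur-containing ring and its carbon chain together; a plain alkyl chain or an open-chain dithiol on the same carbonyl carbon would separate the two. Also open are the true size of both steps and the role of the defined stereocentre in the entering group, for which no opposite stereoisomer is among the compounds shown.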